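The source may report more compounds than this note shows. Statements on the series, on what has been measured and on what is new or still open speak of the compounds shown alone.

The measured compounds are:

Compound 1, `CCNCCCOc1ccc2cc(NC(=O)c3ccc(O)c(CC=C(C)C)c3)c(=O)oc2c1C`; in a functional assay on SK-BR-3 cells (Homo sapiens) for antiproliferative activity (a higher number here means a weaker inhibitor, a lower number a stronger inhibitor), compound 1 gives 720 nM.
Compound 2, `CCCN(CCC)CCCOc1ccc2cc(NC(=O)c3ccc(O)c(CC=C(C)C)c3)c(=O)oc2c1C`; for compound 2 the result in this assay is a limit of the assay, > 50000 nM.
Compound 3, `CC(C)=CCc1cc(C(=O)Nc2cc3ccc(OCCCN(C(C)C)C(C)C)c(C)c3oc2=O)ccc1O`; in this assay compound 3 gives 1600 nM.

Compound 3 thus holds the higher of the two numbers obtained, its nearest neighbour being compound 1, with a 2.2-fold higher number from compound 1 to compound 3 (0.35 log units; beyond the scatter). The limit for compound 2 was reached in one of the three results (the limit of > 50000 nM in this assay, at which 1 of the 3 values shown sits). Every change in this small set sits at the same place, the amine on the chain: an at least 69-fold higher number from compound 1 to compound 2 (1.84 log units; beyond the scatter), whereas an at least 31-fold lower number from compound 2 to compound 3 (1.49 log units; beyond the scatter).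

Compound 4, `CC(C)=CCc1cc(C(=O)Nc2cc3ccc(OCCCNC(C)(C)c4ccccc4)c(C)c3oc2=O)ccc1O`, has not yet been measured in this assay. It differs from compound 3 by (1-methyl-1-phenylethyl)amino in place of diisopropylamino on a saturated chain carbon, three bonds along the chain from an oxygen on an aromatic ring. Among the measured compounds shown here, the steps that bear on it are those between compounds 1, 2 and 3, which show that exchanging groups on this amine can move the number a little or a great deal, in either direction. With nothing pointing firmly one way, a step within the usual scatter is expected, a 1.2-fold lower number from compound 3 to compound 4 (0.09 log units; within the scatter). The estimate for compound 4 in this assay is 1300 nM, within a range from 300 nM to 6000 nM.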

Compound 4, half-maximal inhibitory concentration: 960 nM
Estimate against measurement, compound 4: 1.4-fold (0.13 log units) above; the range from low to high includes it.
By their numbers in this assay, from the lowest: compounds 1, 4 and 3 (each within the scatter of the next, the first and the last beyond it). At a limit, above all of these: compound 2.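

In this assay, (1-methyl-1-phenylethyl)amino puts an aromatic ring on this amine, something none of the earlier amines carried, and yet the number hardly moves: a 1.7-fold lower number from compound 3 to compound 4 (0.22 log units; within the scatter), and a 1.3-fold higher number from compound 1 to compound 4 (0.12 log units; within the scatter), both steps lying within the scatter, so this much larger group is accepted at this place on the chain. Against dipropylamino the same group gives a large step, an at least 52-fold lower number from compound 2 to compound 4 (1.71 log units; beyond the scatter), which shows that the loss seen with compound 2 does not extend to every larger group on this nitrogen. Compound 2 stands at a limit of the assay, not at a number: the limit of > 50000 nM in this assay, at which 1 of the 4 values shown sits.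

From the compounds shown here alone, it remains open whether the aromatic ring itself contributes anything, or whether the branched carbon carrying it is what matters, a question that a benzylamino group or a ring amine such as piperidine or morpholine on the same chain could help to separate. Also open, going by these compounds, is how the number would respond to a shorter or longer chain between the oxygen on the aromatic ring and the amine.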